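A few compounds are considered here, and "the series" means these few. Any claim that something is new, unique, unknown or untested is made for them only; others in the source may bear on it.

Values measured so far in a functional assay on the whole organism with Mus musculus as the target (on this read-out higher numbers stand for an effect only at larger amounts of compound and lower numbers for an effect already at smaller amounts), are these.

- Compound 1 `CCc1c(SC)nc2nc(C(=O)c3ccccc3)cn2c1C` gives 100 mg/kg
- Compound 2 `C=CCc1c(OC)nc2nc(C(=O)c3ccccc3)cn2c1C` gives 100 mg/kg
- Compound 3 `CCc1c(OC)nc2nc(C(=O)c3ccccc3)cn2c1C` gives 200 mg/kg

Compound 3 carries the highest number of the three, yet its gap to each of the others lies within the scatter, so these compounds cannot be ranked. Compound 4 `CCCc1c(OC)nc2nc(C(=O)c3ccccc3)cn2c1C` lengthens the ethyl of compound 3 to propyl (methyl in place of hydrogen on a saturated chain carbon, two bonds along the chain from an aromatic carbon), which is methyl in place of hydrogen on a saturated chain carbon, two bonds along the chain from an aromatic carbon.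

The most relevant evidence is a change on this same chain, which gives a 2.0-fold higher number from compound 2 to compound 3 (0.30 log units; within the scatter). A change elsewhere on the shared core, methoxy in place of methylsulfanyl, gives a 2.0-fold higher number from compound 1 to compound 3 (0.30 log units; within the scatter) and bears on the question only loosely. Neither step exceeds the scatter, so no clear shift is expected here. The estimated step is a 1.3-fold lower number from compound 3 to compound 4 (0.12 log units; within the scatter), which is small. Compound 4 is estimated at 150 mg/kg (expected range 70 mg/kg to 300 mg/kg).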

Compound 4, dose for half-maximal effect: 100 mg/kg
The estimate for compound 4 lay 1.5-fold (0.18 log units) above the measured number; low and high end bracket the measured number.
By their numbers in this assay, from the lowest: compounds 1, 2, 4 and 3 (each within the scatter of the next).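

Lengthening the ethyl of compound 3 to propyl, with methyl in place of hydrogen on a saturated chain carbon, two bonds along the chain from an aromatic carbon, gives a 2.0-fold lower number from compound 3 to compound 4 (0.30 log units; within the scatter) in this assay, so the read-out does not separate these two chains. Exchanging vinyl for ethyl on this chain gives no change at the digits printed from compound 2 to compound 4 (within the scatter), so the chain ending in vinyl and the chain ending in ethyl cannot be told apart here either. No independent measurement bears on these chains, and nothing can be said about why the numbers fall where they do.

Going by these compounds, whether this chain position affects the number at all remains open. A much longer chain such as hexyl, or a chain ending in an amine or a carboxylic acid, could give a step beyond the scatter, which no step shown here does.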